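Working notes: step from compound 2 to compound 3

The compounds below may be only part of what the source reports. "The series", "measured", "known", "first", "only" and "open" are said of these compounds alone.

Measured so far:
compound 1 `COc1ccc(Oc2ccc([C@H]3S[C@@H](C)C(=O)Nc4c3c(C)nn4-c3ccccc3C)cc2)cc1`: 2200 nM
compound 2 `Cc1ccccc1-n1nc(C)c2c1NC(=O)[C@H](C)S[C@@H]2c1ccc(-c2ccco2)cc1`: 3600 nM

In an assay on isolated protein for agonist activity at Bile acid receptor (Homo sapiens), read by AlphaScreen, with a stated time of 30 min (a lower number here means that less compound is needed, a higher number that more compound is needed for the effect), compound 1 gives 2200 nM and compound 2 gives 3600 nM. Compound 2 stands at the highest of the two numbers, yet the step of a 1.6-fold higher number from compound 1 to compound 2 (0.21 log units; within the scatter) lies within the scatter, so no order is claimed. Compound 3 `Cc1ccccc1-n1nc(C)c2c1NC(=O)[C@H](C)S[C@@H]2c1ccc(OCc2ccccc2)cc1` differs from compound 2 by benzyloxy in place of furan-2-yl on an aromatic carbon. Going by the values given here, only the step of a 1.6-fold higher number from compound 1 to compound 2 (0.21 log units; within the scatter) bears on it: an exchange of one group on the aromatic carbon for another, with little effect. Nothing beyond the scatter is therefore expected in this assay, direction unknown. Compound 3 is expected at 3000 nM (1000 nM to 9000 nM), an estimated step of a 1.2-fold lower number from compound 2 to compound 3 (0.08 log units; within the scatter).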

Compound 3, half-maximal effective concentration: "not active" (no number reported)
Compound 3: no number reported; there is nothing to compare the estimate with.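

Going by these compounds alone, compound 3 is reported as "not active" in this assay without a number, so no step from compound 2 to compound 3 can be read. As far as these compounds go, how far benzyloxy in place of furan-2-yl shifts the number remains open. No measured evidence bears on this result.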